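The source may report more compounds than this note shows. Statements on the series, on what has been measured and on what is new or still open speak of the compounds shown alone.

Compound 1 `Oc1ccc(Cn2cnc(F)c2)c2cccnc12`: 34300 nM
Compound 2 `CC(=O)Oc1ccc(Cn2ccnc2)c2cccnc12`: "not determined" (no result reported)
Compound 3 `CC(C)(CCl)C(=O)Oc1ccc(Cn2ccnc2)c2cccnc12`: 12400 nM

These are readings from a functional assay on MDA-MB-231 cells (Homo sapiens) for antiproliferative activity, read by luminescence, with a stated time of 72 h; a higher number here means a weaker inhibitor, a lower number a stronger inhibitor. Compound 2 has no place on this scale, since its entry is "not determined" (no result reported), so it offers no number to start from. Compound 4 `CC(=O)Oc1ccc(Cn2cnc(F)c2)c2cccnc12` has not yet been measured. The change under study is fluoro in place of hydrogen on an aromatic carbon. Without a starting number, neither the size nor the direction of this step can be read from the data.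

The nearest guides are compound 1, which carries the same fluoro group and gives 34300 nM, and compound 3, which lacks it and gives 12400 nM. Those two differ in more than one place, so the gap between their values cannot be assigned to a single change. The expectation in this assay is a value in the same region as these two, with no clear direction. Compound 4 is estimated at about 22000 nM, with an expected range of 9000 nM to 55000 nM.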

Compound 4, half-maximal inhibitory concentration: 2200 nM
Compound 4: middle estimate off by 10-fold (1.00 log units), on the high side; the measured number lies below the stated range.
By their numbers in this assay, from the lowest: compound 4; then compound 3; then compound 1.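

In this assay, the one-place change of acetyl in place of hydrogen on an oxygen on an aromatic ring gives a 16-fold lower number from compound 1 to compound 4 (1.19 log units; beyond the scatter), a large step beyond the usual scatter. Going by these compounds alone, this is the first step here with a number at both ends, and it shows that the group on this oxygen can matter a great deal for this read-out, at least with fluoro present on the five-membered aromatic ring. Nothing here accounts for why the number falls.

As far as these compounds go, the step of fluoro in place of hydrogen cannot be read, since compound 2 has no number, so the part played by the fluoro remains unknown. Also open, from the compounds shown here alone, is how other groups on this oxygen, such as a methyl ether or a carbamate, would compare with acetyl.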